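A few compounds are considered here, and "the series" means these few. Any claim that something is new, unique, unknown or untested is made for them only; others in the source may bear on it.

Compound 1 `CCCOCNc1n[n+]([O-])c2ccccc2[n+]1[O-]` and compound 2 `CC(C)CCOCNc1n[n+]([O-])c2ccccc2[n+]1[O-]` share one core and differ only in the chain that hangs from it. In a functional assay on PC-3 cells (Homo sapiens) for cytotoxicity, read by MTT assay, with a stated time of 72 h (on this read-out higher numbers stand for weaker inhibition and lower numbers for stronger inhibition), compound 1 gives 7400 nM, while compound 2 gives 7520 nM, so compound 2 stands with compound 1, the two numbers indistinguishable within the scatter. Going by the values given here, the step of a 1.0-fold higher number from compound 1 to compound 2 (0.01 log units; within the scatter) is the only measured step, and it is flat. Compound 3 `CCCCCCCOCNc1n[n+]([O-])c2ccccc2[n+]1[O-]` carries pentyl in place of isopropyl on a saturated chain carbon, two bonds along the chain from an oxygen on a saturated carbon. Because that earlier chain change a 1.0-fold higher number from compound 1 to compound 2 (0.01 log units; within the scatter) moved nothing, compound 3 is expected to show a 1.0-fold lower number from compound 2 to compound 3 (0.00 log units; within the scatter), landing near 7500 nM, within a range of 3500 nM to 16000 nM.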

Compound 3, half-maximal inhibitory concentration: 390 nM
The estimate for compound 3 lay 19-fold (1.28 log units) above the measured number; measured number below the stated range.
By their numbers in this assay, from the lowest: compound 3; then compounds 1 and 2 (each within the scatter of the next).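

The flat result from the earlier pair does not hold for every chain at this position. In this assay, pentyl in place of isopropyl gives a 19-fold lower number from compound 2 to compound 3 (1.29 log units; beyond the scatter), and butyl in place of hydrogen, three bonds along the chain from the oxygen, gives a 19-fold lower number from compound 1 to compound 3 (1.28 log units; beyond the scatter), so stronger inhibition appears only with the heptyl chain of compound 3. No measurement given here explains this drop.

Still open, on these data alone, is whether a decyl chain would lower the number further or raise it again. As far as these compounds go, a chain bearing an amine or a carboxylic acid is equally open.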